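The compounds below may be only part of what the source reports. "The series", "measured", "known", "first", "only" and "open" are said of these compounds alone.

In a functional assay on NCI-H1975 cells (Homo sapiens) for antiproliferative activity, read by MTT assay, with a stated time of 72 h (on this read-out lower numbers stand for stronger inhibition and higher numbers for weaker inhibition), the three measured compounds sit fairly close together. Compound 1 `COc1cc2ncnc(Nc3ccc(Cl)cc3)c2cc1OCCCCC(=O)Nc1ccc(S(N)(=O)=O)cc1` gives 31800 nM, and compound 2 `COc1cc2ncnc(Nc3ccc(F)c(Br)c3)c2cc1OCCCCC(=O)Nc1ccc(S(N)(=O)=O)cc1` gives 31600 nM; between them the step is a 1.0-fold lower number from compound 1 to compound 2 (0.00 log units; within the scatter). Compound 3 `COc1cc2ncnc(Nc3cccc(Cl)c3F)c2cc1OCCCCC(=O)Nc1ccc(S(N)(=O)=O)cc1` gives 6930 nM, the lowest of the three numbers, and it reaches that point by a 4.6-fold lower number from compound 1 to compound 3 (0.66 log units; beyond the scatter) and by a 4.6-fold lower number from compound 2 to compound 3 (0.66 log units; beyond the scatter). Compound 4 `COc1cc2ncnc(Nc3ccccc3)c2cc1OCCCCC(=O)Nc1ccc(S(N)(=O)=O)cc1` has not yet been measured. It differs from compound 3 by phenyl in place of 3-chloro-2-fluorophenyl on a nitrogen on an aromatic ring. The two steps that bear on this change are the ones leading into compound 3: each moved the number by a modest amount, whereas the exchange between compound 1 and compound 2 moved nothing beyond the scatter. Within the data shown here, no measured compound carries a bare phenyl on this nitrogen, so the number for compound 4 cannot be read off directly. The change from compound 3 to compound 4 removes exactly the grouping that sets compound 3 apart, and a return toward the numbers of compound 1 and compound 2 is therefore expected. Compound 4 is estimated in this assay at 25000 nM, with a range from 8000 nM to 80000 nM. That estimate corresponds to an expected step of a 3.6-fold higher number from compound 3 to compound 4 (0.56 log units; beyond the scatter).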

Compound 4, half-maximal inhibitory concentration: 14100 nM
Beside the measured number, compound 4's estimate is 1.8-fold (0.25 log units) above it; measured number inside the range.
By their numbers in this assay, from the lowest: compound 3; then compound 4; then compounds 2 and 1 (each within the scatter of the next).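

In this assay the bare phenyl gives the first reference point at this nitrogen, and it falls among the halogenated rings rather than at the weak end: removing the chloro and fluoro of compound 3 costs only a 2.0-fold higher number from compound 3 to compound 4 (0.31 log units; beyond the scatter), a modest step. Halogens on this ring therefore do not act in one direction, since a 2.2-fold lower number from compound 2 to compound 4 (0.35 log units; beyond the scatter) and a 2.3-fold lower number from compound 1 to compound 4 (0.35 log units; beyond the scatter) show that phenyl gives a lower number than 3-bromo-4-fluorophenyl and 4-chlorophenyl, while 3-chloro-2-fluorophenyl alone gives a lower number than phenyl. The last of these steps is the cleanest, a hydrogen in place of chloro on an aromatic carbon, and together the steps show that the kind and placing of the halogens matter more than their presence, though nothing shown here explains the differences.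

The compounds shown leave open whether the chloro or the fluoro of compound 3 accounts for its gain, since no ring here carries either one alone in that arrangement. They also leave open how this nitrogen's ring would respond to a methoxy group, an amine or a nitrile, or to a pyridine in place of the phenyl.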